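The source may hold more compounds than are shown below. What is called first, only, known or untested is meant among the compounds shown, and "the series" means these compounds.

Compound 1 `CCN(CC)c1cc2[nH]c(C3CCCCC3)nc2cc1NC(=O)c1ccc(N(C)C)cc1` and compound 2 `CN(C)c1cc2[nH]c(C3CCCCC3)nc2cc1NC(=O)c1ccc(F)cc1F` share one core. In an ADME assay on Vero cells (Chlorocebus sabaeus) for cytotoxicity, read by resazurin assay, with a stated time of 3 days (a lower number here means a stronger inhibitor, a higher number a weaker inhibitor), compound 1 gives "not determined" (no result reported). Compound 2 in this assay reaches only a limit of the assay, > 100 ug/mL, a boundary rather than a number; its position is that of the limit of > 100 ug/mL in this assay, at which 1 of the 2 values shown sits. Compound 3 `CCN(CC)c1cc2[nH]c(C3CCCCC3)nc2cc1NC(=O)c1ccc(F)cc1F` differs from compound 2 by diethylamino in place of dimethylamino on an aromatic carbon. Among the measured compounds shown here, no measured pair shows this change, and in this assay the step is expected to stay within the usual scatter, in no favoured direction. Compound 3 is estimated at 120 ug/mL, between 50 ug/mL and 300 ug/mL, most likely again reported as a limit. The expected step is a step that the limit leaves unreadable from compound 2 to compound 3.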

Compound 3, half-maximal inhibitory concentration: > 100 ug/mL
Compound 3: only a limit was reported (the forecaster's own chance of this, stated with the estimate: 70%); the middle value is on the limit's open side.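

Among the compounds shown here, compound 2 and compound 3 both reach only a limit of the assay, so no step between them can be read: the limit of > 100 ug/mL in this assay, at which 2 of the 3 values shown sit.

As far as these compounds go, the actual value of each compound in this assay stays open, and with it the effect of diethylamino in place of dimethylamino.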